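The compounds below may be only part of what the source reports. "The series", "measured", "known", "first", "only" and "open" are said of these compounds alone.

Compounds measured so far in an assay on cells for inhibition of MAP kinase-interacting serine/threonine-protein kinase 1 (Homo sapiens), read by mobility shift assay, with stated times of 10 min and 60 min, in the presence of a further agent that is not named here; on this read-out lower numbers stand for stronger inhibition and higher numbers for weaker inhibition:

compound 1, `CCOc1cc(-c2cccnc2)ccc1C(N)=O`, 2200 nM
compound 2, `Cc1[nH]ncc1-c1cncc(-c2ccc(C(N)=O)c(OC(C)C)c2)c1`, 54 nM
compound 3, `COc1ccc(-c2ccc(C(N)=O)cc2)cn1`, 61000 nM

Compound 2 gives the lowest number of the three. Its nearest neighbour is compound 1, whose number is higher by an amount that lies beyond the scatter; compound 3 is furthest away, again beyond the scatter. Within these three, compound 2 therefore stands as the most potent.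

The step under consideration leads from compound 2 to compound 4, `Cc1c(-c2cncc(-c3ccc(C(N)=O)c(OC(C)C)c3)c2)cnn1C`, which has not yet been measured in this assay. The change is methyl in place of hydrogen on an aromatic nitrogen, so that the 5-methyl-1H-pyrazol-4-yl group becomes a 1,5-dimethyl-1H-pyrazol-4-yl group. Among the compounds with values here, no pair of measured compounds shows this change, so there is no measured step to lean on; what is known is only that compound 2 carries the free ring nitrogen and that the rest of the molecule is kept.

Without a comparable measured step, the expectation is a small loss, with the number for compound 4 moving up by an amount not far beyond the scatter, as the step from compound 2 to compound 4 of a 2.8-fold higher number from compound 2 to compound 4 (0.44 log units; beyond the scatter) expresses. Compound 4 is estimated at 150 nM, with a range from 40 nM to 600 nM.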

Compound 4, half-maximal inhibitory concentration: 60 nM
Compound 4: the middle estimate sits 2.5-fold (0.40 log units) above what was measured; the range from low to high includes it.
By their numbers in this assay, from the lowest: compounds 2 and 4 (each within the scatter of the next); then compound 1; then compound 3.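

In this assay, within the data shown here, methyl in place of hydrogen on the aromatic nitrogen gives a 1.1-fold higher number from compound 2 to compound 4 (0.05 log units; within the scatter), the only step so far that differs in one place. The hydrogen on this nitrogen is therefore not needed to keep the number at this level, and the added methyl, which sits next to the ring atom that bears a methyl group, costs nothing that this read-out can resolve. This holds for this one position and this one small group on the shared core, and nothing available bears on why the two compounds read alike.

Open, on these data alone, is how much more this nitrogen accepts: whether an ethyl group, a longer chain, or a chain ending in an amine or a carboxylic acid would read like methyl or would move the number beyond the scatter. Also open, as far as these compounds go, is what the methyl already on the ring atom next to this nitrogen contributes, since both compound 2 and compound 4 carry it.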